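Biphenyl cyclohexyl carbamates: a sulfamoyl replaces a benzyl

The compounds below may be only part of what the source reports. "The series", "measured", "known", "first", "only" and "open" are said of these compounds alone.

The measured compounds are:
compound 1, `Cc1cccc(-c2cccc(OC(=O)NC3CCCCC3)c2)c1`, with 61.8 nM;
compound 2, `O=C(NC1CCCCC1)Oc1cccc(-c2cccc(OC(=O)NC3CCCCC3)c2)c1`, with 361 nM;
compound 3, `O=C(NC1CCCCC1)Oc1cccc(-c2cccc(Cc3ccccc3)c2)c1`, with 1860 nM.

These three share the same cyclohexyl carbamate on a biphenyl and differ only in the group carried on the far ring. In an assay on cell membranes for binding affinity to Fatty-acid amide hydrolase 1 (Rattus norvegicus) (a higher number here means a weaker inhibitor, a lower number a stronger inhibitor), compound 3 gives the highest number of the three. Its nearest neighbour is compound 2, and the step of a 5.2-fold higher number from compound 2 to compound 3 (0.71 log units; beyond the scatter) is modest, while the step of a 30-fold higher number from compound 1 to compound 3 (1.48 log units; beyond the scatter) is large: putting a phenyl onto the methyl of compound 1 costs most of the potency.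

Compound 4, `NS(=O)(=O)c1cccc(-c2cccc(OC(=O)NC3CCCCC3)c2)c1`, is not yet measured. It differs from compound 3 in one place: sulfamoyl in place of benzyl on an aromatic carbon. Both measured steps that end at compound 3 point the same way: the benzyl is the worst of the three substituents tried, and the smaller groups of compound 1 and compound 2 give lower numbers. Removing the benzyl in favour of a sulfamoyl, a group of four heavy atoms, is therefore expected to bring the number down sharply, most likely to the region of compound 1 or below it. The expected step is a 47-fold lower number from compound 3 to compound 4 (1.67 log units; beyond the scatter). Compound 4 is estimated at 40 nM in this assay, with a range from 8 nM to 200 nM.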

Compound 4, half-maximal inhibitory concentration: 26.5 nM
Beside the measured number, compound 4's estimate is 1.5-fold (0.18 log units) above it; low and high end bracket the measured number.
By their numbers in this assay, from the lowest: compound 4; then compound 1; then compound 2; then compound 3.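

Compound 4 shows that the methyl of compound 1 is not the best group yet seen at this position, since the sulfamoyl goes lower in this assay, with a 2.3-fold lower number from compound 1 to compound 4 (0.37 log units; beyond the scatter), and compound 4 now gives the lowest number of the four. The sulfamoyl, which brings a hydrogen-bond donor and two hydrogen-bond acceptors and has no ring, also stands far from the two larger groups, with a 70-fold lower number from compound 3 to compound 4 (1.85 log units; beyond the scatter) and a 14-fold lower number from compound 2 to compound 4 (1.13 log units; beyond the scatter). The earlier compounds shown here could be read as a simple rule that smaller groups give lower numbers, but the four together do not follow it: compound 1 goes against it, its methyl being smaller than the sulfamoyl, and so does compound 2, whose (cyclohexylcarbamoyl)oxy has more heavy atoms than the benzyl of compound 3 yet gives the lower number.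

The compounds shown leave open whether a methylsulfonyl group, which keeps the sulfur and both oxygens of the sulfamoyl but lacks its nitrogen, or a carboxylic acid at this position would hold the same gain. Nothing presented here accounts for the order of the four groups.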